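A few compounds are considered here, and "the series" means these few. Any claim that something is new, unique, unknown or untested is made for them only; others in the source may bear on it.

In a functional assay on MCF7 cells (Homo sapiens) for antiproliferative activity, read by MTT assay, with a stated time of 72 h (on this read-out higher numbers stand for weaker inhibition and lower numbers for stronger inhibition), compound 1 (`COc1cc(-c2ncnn2-c2cccc(N)c2)cc(OC)c1OC`) gives > 10000 nM, which is a limit and not a number. Compound 2 (`COc1cc(-n2ncnc2-c2ccc(Cl)cc2)cc(OC)c1OC`), which also carries 4-chlorophenyl, gives > 10000 nM, likewise a limit. Compound 3 (`COc1cc(-n2ncnc2-c2ccc(OC(F)(F)F)cc2)cc(OC)c1OC`) gives > 10000 nM, again a limit. Going by the values given here, the series so far therefore shows (the limit of > 10000 nM in this assay, at which 3 of the 3 values shown sit).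

Compound 4 (`COc1cc(-c2ncnn2-c2ccc(Cl)cc2)cc(OC)c1OC`) has 4-chlorophenyl in place of 3-aminophenyl on an aromatic nitrogen of the core of compound 1 (4-chlorophenyl in place of 3-aminophenyl on an aromatic nitrogen). Among the compounds with values here, the one measured step is a step that the two limits leave unreadable from compound 2 to compound 3, so it offers no size to carry over. In this assay the expected step, a number no higher from compound 1 to compound 4 (the limit leaves the size open), is none beyond the scatter, in either direction. For compound 4 the estimate is 10000 nM, with an expected range of 3000 nM to 30000 nM, and a reported limit is the likely outcome.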

Compound 4, half-maximal inhibitory concentration: > 10000 nM
Compound 4: a limit, no number; the forecaster's own chance of this, stated with the estimate: 75%; the middle value lies on the limit itself.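

Compound 1 and compound 4 both give only limits, so the step between them cannot be read. The compounds shown leave open which change, if any, would give a readable number in this assay.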